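Halogen swap on the shared core: iodo to chloro

This account rests on a few compounds, and the source may have more. Where it says the series, first, only, none or still open, it means among the compounds named here.

Measured so far:
compound 1 `COc1ccc(Cn2c(=O)nc(NCCNC(=N)N)n(Cc3ccc(I)cc3)c2=O)cc1` — 0.039 nM
compound 2 `Cc1ccc(Cn2c(NCCNC(=N)N)nc(=O)n(Cc3ccc(C(F)(F)F)cc3)c2=O)cc1` — 0.000033 nM
compound 3 `CCc1ccc(Cn2c(=O)nc(NCCNC(=N)N)n(Cc3ccc(OC)cc3)c2=O)cc1` — 0.0058 nM

In a functional assay on the whole organism (strain C57Bl/6) for inhibition, with Mus musculus as the target, with a stated time of 180 min, at 48 degrees C (on this read-out lower numbers stand for an effect already at smaller amounts and higher numbers for an effect only at larger amounts of compound), compound 1 gives the highest of the three numbers. Compound 3 lies nearest to it, beyond the scatter; compound 2 lies furthest away, also beyond the scatter. For the measured compounds named here, neither pair differs in one place only, so no single step is drawn between them.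

Compound 4 `COc1ccc(Cn2c(=O)nc(NCCNC(=N)N)n(Cc3ccc(Cl)cc3)c2=O)cc1` is not yet measured. Against compound 1 the change is chloro in place of iodo on an aromatic carbon, with no change in count of donors, acceptors or charge. Going by the values given here, no measured pair shows this exchange, so there is no step to lean on. A small move, or none beyond the scatter, is expected: a 1.3-fold lower number from compound 1 to compound 4 (0.11 log units; within the scatter). Compound 4 is estimated at 0.03 nM, within 0.005 nM to 0.2 nM.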

Compound 4, half-maximal effective concentration: 0.0044 nM
Compound 4: middle estimate off by 6.8-fold (0.83 log units), on the high side, outside the stated range (below it).
By their numbers in this assay, from the lowest: compound 2; then compounds 4 and 3 (each within the scatter of the next); then compound 1.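

In this assay, for the compounds shown here, the exchange of 4-iodobenzyl for 4-chlorobenzyl gives an 8.9-fold lower number from compound 1 to compound 4 (0.95 log units; beyond the scatter) and is the first single-place step. The halogen on this aromatic carbon therefore matters: with the rest of compound 1 held fixed, this exchange alone moves the read-out beyond the scatter. Nothing available explains the size of this move.

From the compounds shown here alone, whether bromo or fluoro on this carbon would extend the iodo-to-chloro direction remains open. So does the effect of an amine or a carboxylic acid here, and whether the exchange behaves alike with another group in place of the methoxybenzyl.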